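This account rests on a few compounds, and the source may have more. Where it says the series, first, only, none or still open, it means among the compounds named here.

Of the compounds shown here, two of a shared core have been tested so far, and both were measured in an ADME assay on Vero cells (Chlorocebus sabaeus) for cytotoxicity, read by MTT assay; a higher number here means a weaker inhibitor, a lower number a stronger inhibitor. Compound 1, with the structure `C/C(=N\NC(=O)COc1cccc2ccccc12)c1ccc(-n2c(C)ccc2C)cc1`, gives a reading of 277000 nM in this assay. Compound 2, with the structure `C/C(=N\NS(=O)(=O)c1ccc(C)cc1)c1ccc(-n2c(C)ccc2C)cc1`, gives 279000 nM in this assay. Compound 1 carries the lower of the two numbers, but the gap to compound 2 lies within the scatter of repeated measurements, so the two readings cannot be told apart.

The next compound to be tested is compound 3, with the structure `C/C(=N\NC(=O)COc1ccc2ccccc2c1)c1ccc(-n2c(C)ccc2C)cc1`. It is built from the same atoms as compound 1, joined differently: naphthalen-2-yl in place of naphthalen-1-yl on an oxygen on a saturated carbon.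

Among the compounds with values here, no pair of measured compounds shows what such a rearrangement does to the reading in this assay. As both measured compounds sit close together, the expectation for compound 3 is a step from compound 1 of about no change at the digits printed from compound 1 to compound 3 (within the scatter), that is, nothing beyond the scatter in either direction. The estimated reading for compound 3 in this assay is 277000 nM, within a range from 140000 nM to 550000 nM.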

Compound 3, half-maximal inhibitory concentration: 255000 nM
Compound 3: the middle estimate sits 1.1-fold (0.04 log units) above what was measured, within the range that was stated.
By their numbers in this assay, from the lowest: compounds 3, 1 and 2 (each within the scatter of the next).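

Within the data shown here, the swap of naphthalen-2-yl in place of naphthalen-1-yl on an oxygen on a saturated carbon is the first single change that can be read directly in this assay, and it amounts to a 1.1-fold lower number from compound 1 to compound 3 (0.04 log units; within the scatter). At this place, then, the two ways of attaching the same group cannot be told apart by this reading, even though the atoms are joined differently; for this one pair, the point of attachment leaves no mark that rises above the normal variation between repeated measurements. Nothing measured here offers an explanation for this, so the result stands as an observation without a known cause.

Going by these compounds, what remains open is whether this place is tolerant in general or only of these two closely related groups, since a plain phenyl group, a carboxylic acid or an amine on the same oxygen could still move the reading beyond the scatter. On these data alone, it is also open whether a longer chain between that oxygen and the rest of the molecule would leave the reading just as unchanged.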